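This account rests on a few compounds, and the source may have more. Where it says the series, first, only, none or still open, it means among the compounds named here.

In a functional assay on IMR-32 cells (Homo sapiens) for antiproliferative activity, with a stated time of 72 h (on this read-out lower numbers stand for stronger inhibition and higher numbers for weaker inhibition), compound 1 `Cc1cc(C)cc(C(=O)N(CCC(=O)NCc2ccccc2)Cc2ccc(C(=O)NO)cc2)c1` gives 1390 nM. Compound 2 `O=C(CCN(Cc1ccc(C(=O)NO)cc1)C(=O)c1ccccc1)NCc1ccccc1`, at 2360 nM, sits within the scatter of compound 1, while compound 3 `CN(C)c1ccc(C(=O)N(CCC(=O)NCc2ccc(Cl)cc2)Cc2ccc(C(=O)NO)cc2)cc1`, at 310 nM, lies clearly lower than both. Compound 4 `CN(C)c1ccc(C(=O)N(CCC(=O)NCc2ccccc2)Cc2ccc(C(=O)NO)cc2)cc1` keeps the core of compound 1 and makes one change: 4-(dimethylamino)phenyl in place of 3,5-dimethylphenyl on a carbonyl carbon.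

Among the compounds with values here, only one measured step touches the same place, phenyl in place of 3,5-dimethylphenyl on a carbonyl carbon, and it is small: a 1.7-fold higher number from compound 1 to compound 2 (0.23 log units; within the scatter). That single step offers no sign of a large swing here. The other clue is compound 3, which at 310 nM carries the same 4-(dimethylamino)phenyl as compound 4 but also has a chlorine that compound 4 lacks. Within the data shown here, no measured pair separates these two features, so only part of that lower number can be expected to carry over. A moderate move towards stronger inhibition in this assay is therefore expected, though it may not clear the scatter. The expected step is a 2.0-fold lower number from compound 1 to compound 4 (0.30 log units; within the scatter). For compound 4 the estimated value is 700 nM, with an expected range from 280 nM to 1700 nM.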

Compound 4, half-maximal inhibitory concentration: 840 nM
Estimate against measurement, compound 4: 1.2-fold (0.08 log units) below; the range from low to high includes it.
By their numbers in this assay, from the lowest: compound 3; then compounds 4, 1 and 2 (each within the scatter of the next, the first and the last beyond it).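

In this assay, the step of a 1.7-fold lower number from compound 1 to compound 4 (0.22 log units; within the scatter) shows that 4-(dimethylamino)phenyl and 3,5-dimethylphenyl on this carbonyl carbon cannot be told apart, yet a 2.8-fold lower number from compound 2 to compound 4 (0.45 log units; beyond the scatter) shows that adding dimethylamino to the plain phenyl has an effect that clears the scatter. Within the data shown here, compound 4 also separates the two features of compound 3 for the first time: with hydrogen in place of chloro on an aromatic carbon there is a 2.7-fold higher number from compound 3 to compound 4 (0.43 log units; beyond the scatter), so the chloro is tied to a modest part of the low number of compound 3. No available evidence explains either step.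

On these data alone, the chloro step rests on a single pair, so it remains open whether it would hold alongside the 3,5-dimethylphenyl of compound 1 or the phenyl of compound 2. Also open, as far as these compounds go, is how a methoxy group or a morpholine would compare with dimethylamino, and how fluoro or methyl would compare with chloro.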